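Methoxy Added Twice, Read on Fibroblast Cytotoxicity

The compounds below may be only part of what the source reports. "The series", "measured", "known", "first", "only" and "open" are said of these compounds alone.

Compound 1 `COc1ccc(/C=C2\CCC/C(=C\c3cccc(OC)c3OC)C2=O)cc1`: 43500 nM
Compound 2 `COc1ccc(/C=C2\CCC/C(=C\c3cccc(OC)c3OC)C2=O)c(OC)c1`: its value, > 50000 nM, is a limit of the assay
Compound 3 `COc1ccc(/C=C2\CCC/C(=C\c3ccc(OC)c(OC)c3)C2=O)cc1`: 30900 nM

All three were tested in an ADME assay on NHDF cells (Homo sapiens) for cytotoxicity, read by MTT assay, with a stated time of 72 h; on this read-out higher numbers stand for weaker inhibition and lower numbers for stronger inhibition. Compound 1 gives 43500 nM. For compound 2 the assay reports only a limit, > 50000 nM; this is the limit of > 50000 nM in this assay, at which 1 of the 3 values shown sits. The change between them is methoxy in place of hydrogen on an aromatic carbon, and the step is an at least 1.1-fold higher number from compound 1 to compound 2 (0.06 log units; that floor lies within the scatter). Compound 3 gives 30900 nM, which sits within the scatter of the value of compound 1; how the core of compound 3 differs from that of compound 1 is not broken down here.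

Compound 4 `COc1ccc(/C=C2\CCC/C(=C\c3ccc(OC)c(OC)c3)C2=O)c(OC)c1` has not yet been measured. It is made from compound 3 by methoxy in place of hydrogen on an aromatic carbon, the same change as that from compound 1 to compound 2, at a place described in the same words. Because compound 2 reached only (the limit of > 50000 nM in this assay, at which 1 of the 3 values shown sits), the earlier step gives only a floor. On that basis compound 4 is expected to show a 1.3-fold higher number from compound 3 to compound 4 (0.11 log units; within the scatter), a step of the same kind as the earlier one. The value estimated for compound 4 in this assay is 40000 nM, expected between 22000 nM and 70000 nM.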

Compound 4, half-maximal inhibitory concentration: > 50000 nM
Compound 4: no number, only a limit (the forecaster's own chance of this, stated with the estimate: 35%); middle value at least 1.2-fold (0.09 log units) away from the limit.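

In this assay compound 4 gives > 50000 nM, which is a limit of the assay and not a number. Methoxy in place of hydrogen on an aromatic carbon, ortho to a large group, therefore gives only a floor for the step, an at least 1.6-fold higher number from compound 3 to compound 4 (0.20 log units; that floor lies within the scatter). This shows that the change took the second core to the assay limit, as it did the first, but not that its size carries over from one core to the other: the same change on two cores in this assay, an at least 1.1-fold higher number (0.06 log units; that floor lies within the scatter) from compound 1 to compound 2 and an at least 1.6-fold higher number (0.20 log units; that floor lies within the scatter) from compound 3 to compound 4; the limit leaves it open whether they differ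

From the compounds shown here alone, the true size of either step stays open, since neither compound 2 nor compound 4 has a number on this read-out, and neither floor lies beyond the scatter. The compounds shown also leave open what would happen with an ethoxy group, a hydroxyl group or an amine in place of the methoxy group at this position, since methoxy is the only group that enters here.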